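Quinone series: chain extension toward the hydroxyl terminus

The compounds below may be only part of what the source reports. "The series", "measured", "known", "first", "only" and "open" are said of these compounds alone.

Measured so far:
compound 1 `COC1=C(OC)C(=O)C(CCCO)=C(C)C1=O` — 13000 nM
compound 2 `COC1=C(OC)C(=O)C(CCCCCCCCCCn2ccnc2)=C(C)C1=O` — 3000 nM

In a functional assay on HL-60 cells (Homo sapiens) for antiproliferative activity, read by MTT assay, with a stated time of 48 h (on this read-out lower numbers stand for stronger inhibition and higher numbers for weaker inhibition), compound 1 gives 13000 nM, the highest of the two numbers recorded. Within the data shown here, the nearest neighbour, compound 2, gives 3000 nM in this assay, a gap that lies beyond the scatter; the two compounds differ in more than one place, so no single step is drawn between them.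

Compound 3 `COC1=C(OC)C(=O)C(CCCCCO)=C(C)C1=O` is not yet measured. It differs from compound 1 in one place: 2-hydroxyethyl in place of hydroxy on a saturated chain carbon, three bonds along the chain from a double-bonded ring carbon. Among the measured compounds shown here, no step between measured compounds matches this change, so the expected size must be set from the two values alone.

A decrease in the number is expected for compound 3, of a size near the edge of the scatter, a 1.9-fold lower number from compound 1 to compound 3 (0.27 log units; within the scatter). For compound 3 in this assay the estimate is 7000 nM, with a range from 3000 nM to 16000 nM.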

Compound 3, half-maximal inhibitory concentration: 13000 nM
The estimate for compound 3 lay 1.9-fold (0.27 log units) below the measured number, within the range that was stated.
By their numbers in this assay, from the lowest: compound 2; then compounds 1 and 3 (each within the scatter of the next).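

In this assay, among these compounds, the step of 2-hydroxyethyl in place of hydroxy, on a saturated chain carbon, three bonds along the chain from a double-bonded ring carbon, gives no change at the digits printed from compound 1 to compound 3 (within the scatter) and is the first single-place comparison. At this position, the read-out does not separate the 5-hydroxypentyl chain of compound 3 from the 3-hydroxypropyl chain of compound 1, with the hydroxyl terminus kept in both. Nothing in hand bears on why the two chains read alike.

As far as these compounds go, it remains open whether a longer chain ending in hydroxy would depart from compound 1 on this read-out. From the compounds shown here alone, it is also open whether replacing the terminal hydroxy of compound 3 with an amine or a carboxylic acid would move the number.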